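This account rests on a few compounds, and the source may have more. Where it says the series, first, only, none or still open, it means among the compounds named here.

Measured so far:
- compound 1, `CNC(=O)c1cnc(N)c(-c2cc(Cl)cc(Cl)c2Cl)c1`: 24000 nM
- compound 2, `Cn1nccc1C(=O)Nc1ccc(-c2cc(Cl)ccc2Cl)c(N)n1`: 920 nM
- compound 3, `COc1ccc(Cl)c(-c2ccc(NC(=O)c3conc3C)nc2N)c1`: 500 nM

These three compounds were tested in an assay on HEK293 cells for inhibition of sodium channel protein type 10 subunit alpha (Homo sapiens), read by fluorescence; a higher number here means a weaker inhibitor, a lower number a stronger inhibitor. Compound 3 gives 500 nM, and the difference between compound 3 and compound 2 lies within the usual scatter of this assay, so the two cannot be told apart. Compound 1, with its value of 24000 nM, stands well beyond the scatter from compound 3.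

Compound 4, `COc1ccc(Cl)c(-c2ccc(NC(=O)c3ccnn3C)nc2N)c1`, has not yet been measured. It differs from compound 3 in one place: 1-methyl-1H-pyrazol-5-yl in place of 3-methyl-1,2-oxazol-4-yl on a carbonyl carbon. The group that leaves and the group that enters are of the same size, each a five-membered aromatic ring with 2 hetero atoms, 0 hydrogen-bond donors and 2 hydrogen-bond acceptors.

For compound 4 in this assay no step beyond the scatter is expected in either direction, because compound 2, which already carries the entering 1-methyl-1H-pyrazol-5-yl group on its carbonyl carbon, gives 920 nM. The expected step from compound 3 to compound 4 is no change at the digits printed from compound 3 to compound 4 (within the scatter). Compound 4 is therefore estimated at 500 nM, with a likely range from 200 nM to 1300 nM.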

Compound 4, half-maximal inhibitory concentration: 700 nM
Compound 4: the middle estimate sits 1.4-fold (0.15 log units) below what was measured; the measured number falls inside the stated range.
By their numbers in this assay, from the lowest: compounds 3, 4 and 2 (each within the scatter of the next); then compound 1.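

Going by these compounds alone, the first comparisons in one place appear here. In this assay, 1-methyl-1H-pyrazol-5-yl in place of 3-methyl-1,2-oxazol-4-yl on a carbonyl carbon gives a 1.4-fold higher number from compound 3 to compound 4 (0.15 log units; within the scatter), so these two five-membered rings cannot be told apart at this position. With the 1-methyl-1H-pyrazol-5-yl group kept, methoxy in place of chloro on an aromatic carbon gives a 1.3-fold lower number from compound 2 to compound 4 (0.12 log units; within the scatter), so that change cannot be told apart from no change either, and nothing shown offers an explanation for either result.

Only these two rings are shown on the carbonyl carbon, so it remains open whether a phenyl ring or a group carrying an amine there would move the number beyond the scatter. Compound 1 differs from the others in more than one place, so no single change can be read from it.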